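Aortic functional series: carboxyethenyl in place of acetamidomethyl

The source may report more compounds than this note shows. Statements on the series, on what has been measured and on what is new or still open speak of the compounds shown alone.

Measured so far:
compound 1 `COc1ccc(-c2nc(CNC(C)=O)sc2-c2ccc(OC)cc2)cc1` — 8.1 uM
compound 2 `CCOC(=O)C1=C(C)N=C(C)/C(=C(/O)OCC)C1c1nc(-c2ccc(OC)cc2)c(-c2ccc(OC)cc2)s1` — > 32 uM (a limit, not a number)

Among the measured compounds shown here, compound 1 is the only compound with a numerical read-out in a functional assay (aorta) with Rattus norvegicus as the target; on this read-out lower numbers stand for an effect already at smaller amounts and higher numbers for an effect only at larger amounts of compound. Compound 2 sits at the limit of > 32 uM in this assay, at which 1 of the 2 values shown sits, and contributes no number against which compound 1 could be ranked. For the measured compounds named here, no step between measured compounds is available, so the change towards compound 3 `COc1ccc(-c2nc(/C=C/C(=O)O)sc2-c2ccc(OC)cc2)cc1` is judged without a measured precedent. Compound 3 differs from compound 1 by 2-carboxyethenyl in place of acetamidomethyl on an aromatic carbon.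

The step from compound 1 to compound 3 in this assay is expected to be modest, with no confident direction; the estimated step is a 1.5-fold higher number from compound 1 to compound 3 (0.17 log units; within the scatter), which stays near the scatter. For compound 3 the expected value in this assay is 12 uM, with a range from 3 uM to 40 uM.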

Compound 3, concentration for half-maximal effect: 55 uM
Estimate against measurement, compound 3: 4.6-fold (0.66 log units) below; measured number outside the range, above it.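

In this assay the read-out proves sensitive to the group on the aromatic carbon next to the ring nitrogen and the ring sulfur: 2-carboxyethenyl in place of acetamidomethyl gives a 6.8-fold higher number from compound 1 to compound 3 (0.83 log units; beyond the scatter). The two groups match in heavy atoms, hydrogen-bond donors, hydrogen-bond acceptors and net charge, so these counts alone do not set the read-out at this position. Nothing measured here accounts for the size of this step.

Open, from the compounds shown here alone, is whether a saturated 2-carboxyethyl chain or the ethyl ester of the acid would read closer to compound 1 or to compound 3 at this position. Also open, going by these compounds, is how an aminomethyl group or a longer amide chain would read on the same carbon.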